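Notes: methyl on the ring amine of compound 3

This account rests on a few compounds, and the source may have more. Where it says the series, first, only, none or still open, it means among the compounds named here.

Measured so far:
compound 1 `Cc1cn2cc(-c3cc4ccc(N5CCN(C)CC5)cc4oc3=O)nc2cn1`: 2.7 10^-6 cm/s
compound 2 `Cc1cn2cc(-c3cc4ccc(N5CCN(C)CC5)cc4oc3=O)nc2c(C)n1`: 1.4 10^-6 cm/s
compound 3 `Cc1cn2nc(-c3cc(=O)n4cc(N5CCNCC5)ccc4n3)cc2c(C)n1`: 14 10^-6 cm/s

In an ADME assay on Caco-2 cells (Homo sapiens) for permeability (on this read-out lower numbers stand for lower permeability and higher numbers for higher permeability), compound 3 gives the highest number of the three, with compound 1 and compound 2 both beyond the scatter below it. The next compound in the series is compound 4 `Cc1cn2nc(-c3cc(=O)n4cc(N5CCN(C)CC5)ccc4n3)cc2c(C)n1`, which differs from compound 3 by methyl in place of hydrogen on an amine nitrogen in a ring. Among the compounds with values here, the only step measured so far is a 1.9-fold lower number from compound 1 to compound 2 (0.29 log units; within the scatter), a change on an aromatic carbon that does not match the present one, so no measured step bears directly on it. Compound 1 and compound 2, which already carry the methyl on the ring amine, sit on a different core, and their values cannot be read as a step. With no guide, compound 4 is expected to stay near compound 3, a step of a 1.2-fold higher number from compound 3 to compound 4 (0.08 log units; within the scatter), within the scatter. The estimate for compound 4 is 17 10^-6 cm/s, with a range from 7 10^-6 cm/s to 40 10^-6 cm/s.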

Compound 4, apparent permeability: 7.5 10^-6 cm/s
Beside the measured number, compound 4's estimate is 2.3-fold (0.36 log units) above it; measured number inside the range.
By their numbers in this assay, from the lowest: compounds 2 and 1 (each within the scatter of the next); then compounds 4 and 3 (each within the scatter of the next).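

In this assay, within the data shown here, the change from piperazin-1-yl to 4-methylpiperazin-1-yl gives a 1.9-fold lower number from compound 3 to compound 4 (0.27 log units; within the scatter), the first reading of a change at this ring nitrogen on a shared core. At this position, on the core of compound 3, the read-out does not separate the hydrogen from the methyl. No supporting data bear on this result. From the compounds shown here alone, whether an ethyl group, an acetyl group or a longer chain on this nitrogen would also stay within the scatter of compound 3 remains open. So does the effect of hydrogen in place of methyl on the core of compound 1.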